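The source may hold more compounds than are shown below. What is called first, only, known or untested is meant among the compounds shown, and "the series" means these compounds.

Measured so far in an ADME assay on BCBL1 cells (Homo sapiens) for cytotoxicity, with a stated time of 7 days; on this read-out higher numbers stand for lower toxicity in this test and lower numbers for higher toxicity in this test:

Compound 1 `CC(C)CSc1nc(N)nc2c1ncn2/C=C1/CC1(CO)CO`: > 20000 nM
Compound 2 `Nc1nc(OCc2ccccc2)c2ncn(/C=C3/CC3(CO)CO)c2n1`: > 20000 nM

Compound 1 gives > 20000 nM, which is a limit of the assay and not a number. Compound 2 gives > 20000 nM, which is also a limit of the assay. Compound 2 therefore has no exact place on the scale of this assay, and the same holds for the other measured compound: the limit of > 20000 nM in this assay, at which 2 of the 2 values shown sit.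

Compound 3 `Nc1nc(N2CCCC2)c2ncn(/C=C3/CC3(CO)CO)c2n1` has pyrrolidin-1-yl in place of benzyloxy on an aromatic carbon, next to the ring nitrogen: pyrrolidin-1-yl in place of benzyloxy on an aromatic carbon.

Within the data shown here, one measured step bears on this change, also a replacement on an aromatic carbon: a step that the two limits leave unreadable from compound 1 to compound 2. Its size cannot be read, so it offers only weak guidance. Among the measured compounds shown here, with only that step to go on, no change beyond the usual scatter is expected in this assay, and no direction can be favoured. The expected step is a step that the limit leaves unreadable from compound 2 to compound 3. The estimate for compound 3 is 25000 nM, with an expected range from 10000 nM to 50000 nM, and a further limit is the likely report.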

Compound 3, half-maximal cytotoxic concentration: > 20000 nM
Compound 3: a limit, no number (the forecaster's own chance of this, stated with the estimate: 80%); the middle value is on the limit's open side.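

In this assay compound 3 gives > 20000 nM, which is a limit of the assay and not a number. Among these compounds, no new step can therefore be read from compound 3 to compound 1 or compound 2. The compounds shown leave open whether isobutylsulfanyl, benzyloxy and pyrrolidin-1-yl differ at all in this test, and at what concentration any compound turns toxic: the limit of > 20000 nM in this assay, at which 3 of the 3 values shown sit.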